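The source may report more compounds than this note shows. Statements on the series, on what has been measured and on what is new or still open speak of the compounds shown alone.

Compound 1 `CC(C)=CCC[C@H](C)c1ccc(C)c(CNCCO)c1O`: 14400 nM
Compound 2 `CC(C)=CCC[C@H](C)c1ccc(C)c(CNCCCCCO)c1O`: 10700 nM
Compound 3 `CCOC(CCN1COc2c([C@@H](C)CCC=C(C)C)ccc(C)c2C1)OCC`: 11300 nM

In a functional assay on MDA-MB-231 cells (Homo sapiens) for inhibition, read by MTT assay, with a stated time of 72 h (on this read-out higher numbers stand for weaker inhibition and lower numbers for stronger inhibition), compound 2 gives 10700 nM. That value sits within the scatter of both other measurements, so the three compounds form one group with no meaningful order among them.

The next compound to consider is compound 4 `CCOC(CCNCc1c(C)ccc([C@@H](C)CCC=C(C)C)c1O)OCC`, which differs from compound 2 by one change: diethoxymethyl in place of 3-hydroxypropyl on a saturated chain carbon, two bonds along the chain from an amine nitrogen. In words, this is diethoxymethyl in place of 3-hydroxypropyl on a saturated chain carbon, two bonds along the chain from an amine nitrogen. Cut one bond further out, the same change reads 5-hydroxypentyl to 3,3-diethoxypropyl.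

Among the compounds with values here, only one measured step changes this same place: a 1.3-fold lower number from compound 1 to compound 2 (0.13 log units; within the scatter). It replaced hydroxy with 3-hydroxypropyl and stayed within the scatter. Within the data shown here, no measured step isolates the new diethoxy end. Compound 3 also carries a 3,3-diethoxypropyl chain and gives 11300 nM, but its structure differs elsewhere too, so it offers only loose support.

No shift beyond the scatter is therefore expected in this assay. The estimated change is a 1.0-fold higher number from compound 2 to compound 4 (0.01 log units; within the scatter).

The expected value for compound 4 is 11000 nM, with an estimated range of 6000 nM to 20000 nM.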

Compound 4, half-maximal inhibitory concentration: 14900 nM
Compound 4: middle estimate off by 1.4-fold (0.13 log units), on the low side; low and high end bracket the measured number.
By their numbers in this assay, from the lowest: compounds 2, 3, 1 and 4 (each within the scatter of the next).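

At this place, on a saturated chain carbon, two bonds along the chain from an amine nitrogen, diethoxymethyl in place of 3-hydroxypropyl gives a 1.4-fold higher number from compound 2 to compound 4 (0.14 log units; within the scatter) in this assay. Diethoxymethyl in place of hydroxy at the same place gives a 1.0-fold higher number from compound 1 to compound 4 (0.01 log units; within the scatter), so the end of the chain has now been changed in two further ways without leaving the scatter. The group that enters has 0 hydrogen-bond donors and 7 heavy atoms, against 1 donor and 4 heavy atoms for 3-hydroxypropyl, and across compounds 1, 2 and 4 even this difference in make-up comes with no difference that can be read in this cell assay.

With all three of these compounds inside the scatter of one another, it remains open whether any chain end at this place can move the number beyond the scatter. A chain ending in a carboxylic acid or in a second amine would be a different kind of end, and the compounds shown say nothing about either.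

No measurement at hand offers an explanation for this result.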